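Side-chain trimming in this series: compound 3 to compound 4

This account rests on a few compounds, and the source may have more. Where it says the series, first, only, none or still open, it means among the compounds named here.

Measured so far in a functional assay on the whole organism (Tail, strain ICR) with Mus musculus as the target, in the tail flick test, with a stated time of 30 min, at a dose of 25 umol/kg by the oral route; on this read-out higher numbers stand for a stronger effect at the one dose given and lower numbers for a weaker effect:

Compound 1 `CC(C)[C@H](NC(=O)CN(c1nc(Cl)nc2[nH]cnc12)C1CC1)C(=O)OCc1ccccc1`: 33.4%
Compound 2 `O=C(CN(c1nc(Cl)nc2[nH]cnc12)C1CC1)N[C@@H](CC(=O)OCc1ccccc1)C(=O)OCc1ccccc1`: 34.7%
Compound 3 `NC(=O)C[C@H](NC(=O)CN(c1nc(Cl)nc2[nH]cnc12)C1CC1)C(=O)O`: 29.7%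

Compound 3 gives the lowest of the three numbers, yet its gaps to compound 1 and to compound 2 are both within the scatter, so the three read as one level. Compound 4 `C[C@H](NC(=O)CN(c1nc(Cl)nc2[nH]cnc12)C1CC1)C(=O)O` differs from compound 3 by hydrogen in place of carbamoyl on a saturated chain carbon, two bonds along the chain from an amide-type nitrogen and a carbonyl carbon. Within the data shown here, the one measured step, a number 1.3 percentage points higher from compound 1 to compound 2 (within the scatter), also swaps a side-chain group and left the read-out within the scatter; it bears on the present change only loosely, as a sign that side-chain swaps have so far moved little. For compound 4 the expectation in this assay is therefore 30%, within 18% to 42%. The step of a number 0.3 percentage points higher from compound 3 to compound 4 (within the scatter) is expected to stay within the scatter.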

Compound 4, a percentage reported as activity, at one dose (the size of the read-out at that dose, not a potency): 48.1%
Estimate against measurement, compound 4: 18.1 percentage points below; the whole stated range lies below it.
By their numbers in this assay, from the lowest: compounds 3, 1 and 2 (each within the scatter of the next); then compound 4.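

In this assay, among these compounds, this side chain can move the read-out: hydrogen in place of carbamoyl gives a number 18.4 percentage points higher from compound 3 to compound 4 (beyond the scatter) and is the first step beyond the scatter. Carbamoylmethyl to methyl therefore matters on this scaffold, whereas the side-chain swap in a number 1.3 percentage points higher from compound 1 to compound 2 (within the scatter) did not separate its pair. Nothing measured here bears on why the read-out moved.

From the compounds shown here alone, whether methyl itself contributes, or only the loss of carbamoyl, remains open. A longer chain such as ethyl, or a hydroxymethyl or aminomethyl group at this place, would help separate the two.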